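This account rests on a few compounds, and the source may have more. Where it says the series, first, only, none or still open, it means among the compounds named here.

Of the compounds shown here, three of one shared core have been tested in an ADME assay on L6 cells (Rattus norvegicus) for cytotoxicity; a higher number here means a weaker inhibitor, a lower number a stronger inhibitor. Compound 1 `N=C(N)c1ccc(-c2cc3cc(C(=N)N)ccc3o2)cc1` gives 1900 nM. Compound 2 `N=C(N)c1cccc(-c2cc3cc(C(=N)N)ccc3o2)c1` gives 21200 nM; the difference between the cores of compound 1 and compound 2 is not broken down here. Compound 3 `COc1cc(C(=N)N)ccc1-c1cc2cc(C(=N)N)ccc2o1` gives 157000 nM. The change from compound 1 to compound 3 is methoxy in place of hydrogen on an aromatic carbon, and it made the step of an 83-fold higher number from compound 1 to compound 3 (1.92 log units; beyond the scatter).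

Compound 4 `COc1ccc(C(=N)N)cc1-c1cc2cc(C(=N)N)ccc2o1` has not yet been measured. It arises from compound 2 by methoxy in place of hydrogen on an aromatic carbon. Among the measured compounds shown here, this is the same kind of change as the one from compound 1 to compound 3, but the place is not identical: in compound 3 the methoxy sits meta to a group of 3 heavy atoms, in compound 4 para to it. For the measured compounds named here, only one measured example of this change exists, and it sits on a different core, so the step is expected to point the same way but is not assumed to be as large: beside an 83-fold higher number from compound 1 to compound 3 (1.92 log units; beyond the scatter), the estimated step is a 7.1-fold higher number from compound 2 to compound 4 (0.85 log units; beyond the scatter). Compound 4 is therefore expected to give about 150000 nM in this assay, with a plausible range from 30000 nM to 800000 nM.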

Compound 4, half-maximal inhibitory concentration: 179000 nM
Estimate against measurement, compound 4: 1.2-fold (0.08 log units) below, within the range that was stated.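

In this assay, methoxy in place of hydrogen on an aromatic carbon gave an 8.4-fold higher number from compound 2 to compound 4 (0.93 log units; beyond the scatter), so the number moved the same way on both cores. The size of the step did not carry over, and the gap between the two steps is larger than the usual scatter would allow: the same change on two cores in this assay, an 83-fold higher number (1.92 log units; beyond the scatter) from compound 1 to compound 3 and an 8.4-fold higher number (0.93 log units; beyond the scatter) from compound 2 to compound 4, 9.8-fold (0.99 log units) apart, beyond the scatter of two such steps. Among the compounds shown here, with only two pairs, and with the methoxy in a different place on each, these data show neither whether the core or the place sets the size of the step nor whether a further core would move the same way.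

Methoxy is the only group added in these pairs, so it remains open how a hydroxyl, an amine or a longer chain such as ethoxy would change the number in the same place. Going by these compounds, it also remains open whether a carboxylic acid there would move the number the same way as methoxy on either core.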